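The source may hold more compounds than are shown below. What is called first, only, known or untested is meant among the compounds shown, and "the series" means these compounds.

Compound 1 `CC(C)(C)c1ccc(CNCCCNS(=O)(=O)c2cc(C(F)(F)F)cc(C(F)(F)F)c2)cc1`: 1400 nM
Compound 2 `COc1cccc(CNCCCNS(=O)(=O)c2cc(C(F)(F)F)cc(C(F)(F)F)c2)c1`: 1700 nM
Compound 3 `O=S(=O)(NCCCNCc1ccc(Cl)c(Cl)c1)c1cc(C(F)(F)F)cc(C(F)(F)F)c1`: 1400 nM

The three measured compounds share one core and differ only in the aromatic group on a saturated chain carbon bound to an amine nitrogen. In a functional assay on BXPC-3 cells (Homo sapiens) for inhibition, read by MTT assay, with a stated time of 72 h (a higher number here means a weaker inhibitor of growth, a lower number a stronger inhibitor of growth), compound 3 stands level with compound 1, the two together giving the lowest numbers of the three, and compound 2 is the furthest away from it, yet every gap among them is small: a 1.2-fold higher number from compound 1 to compound 2 (0.08 log units; within the scatter), no change at the digits printed from compound 1 to compound 3 (within the scatter) and a 1.2-fold lower number from compound 2 to compound 3 (0.08 log units; within the scatter) all lie within the scatter.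

Compound 4 `COc1ccc(CNCCCNS(=O)(=O)c2cc(C(F)(F)F)cc(C(F)(F)F)c2)cc1` is the next variation at the same place: 4-methoxyphenyl in place of 3,4-dichlorophenyl on a saturated chain carbon bound to an amine nitrogen. For the measured compounds named here, the steps that bear on this are the three exchanges of the aromatic group already seen, none of which moved this assay beyond the scatter, and compound 2 already carries a methoxyphenyl with a similar result. The expectation for compound 4 is therefore no step beyond the scatter, a 1.1-fold higher number from compound 3 to compound 4 (0.06 log units; within the scatter). Compound 4 is estimated at 1600 nM, with a range from 900 nM to 2900 nM.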

Compound 4, concentration for 50% growth inhibition: 1300 nM
Beside the measured number, compound 4's estimate is 1.2-fold (0.09 log units) above it, within the range that was stated.
By their numbers in this assay, from the lowest: compounds 4, 1, 3 and 2 (each within the scatter of the next).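

In this assay, the methoxy group sits in 3-methoxyphenyl or in 4-methoxyphenyl with no real separation, as the exchange gives a 1.3-fold lower number from compound 2 to compound 4 (0.12 log units; within the scatter). Methoxy in place of tert-butyl on an aromatic carbon gives a 1.1-fold lower number from compound 1 to compound 4 (0.03 log units; within the scatter), and 4-methoxyphenyl in place of 3,4-dichlorophenyl, which brings in a hydrogen-bond acceptor where the group it replaces has none, gives a 1.1-fold lower number from compound 3 to compound 4 (0.03 log units; within the scatter), so all four aromatic groups on this saturated chain carbon bound to an amine nitrogen remain within the scatter of one another. Nothing available explains why these exchanges leave the growth inhibition so flat.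

On these data alone, it remains open whether this flat picture would hold for an aromatic group carrying a carboxylic acid or an amine, or for a cyclohexyl group replacing the aromatic ring. A longer chain in the shared core is also an open question.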